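A Fluoro Step on Compound 2

The compounds below may be only part of what the source reports. "The series", "measured", "known", "first", "only" and "open" are said of these compounds alone.

Among the measured compounds shown here, in a functional assay on CWR22R cells (Homo sapiens) for cytotoxicity, read by MTT assay, with a stated time of 72 h (on this read-out higher numbers stand for weaker inhibition and lower numbers for stronger inhibition), compound 2 `CC1=C(/C=C/C(=O)/C=C/c2ccccc2)C(C)(C)CCC1O` gives 8000 nM, the highest number of the three measured so far. Compound 1 `CC1=CCCC(C)(C)C1/C=C/C(=O)/C=C/c1ccc(C(F)(F)F)cc1` reads 3300 nM and compound 3 `CC1=C(/C=C/C(=O)/C=C/c2cccc(C(F)(F)F)c2)C(C)(C)CCC1O` reads 1700 nM, both beyond the scatter from compound 2.

Compound 4 `CC1=C(/C=C/C(=O)/C=C/c2ccc(F)cc2)C(C)(C)CCC1O` has not yet been measured in this assay. Its difference from compound 2 is fluoro in place of hydrogen on an aromatic carbon, which takes phenyl to 4-fluorophenyl.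

For the measured compounds named here, only one measured step bears on this change. Trifluoromethyl in place of hydrogen on an aromatic carbon gave a 4.7-fold lower number from compound 2 to compound 3 (0.67 log units; beyond the scatter), a modest step beyond the scatter. Fluoro is a different group, so that step is a guide to direction rather than a measure of size. The expected step is a 1.6-fold lower number from compound 2 to compound 4 (0.20 log units; within the scatter), in the same direction but smaller, and not beyond the scatter. For compound 4 the estimated value is 5000 nM, with an expected range of 2200 nM to 11000 nM.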

Compound 4, half-maximal inhibitory concentration: 7500 nM
Beside the measured number, compound 4's estimate is 1.5-fold (0.18 log units) below it; the measured number falls inside the stated range.
By their numbers in this assay, from the lowest: compounds 3 and 1 (each within the scatter of the next); then compounds 4 and 2 (each within the scatter of the next).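

In this assay, fluoro in place of hydrogen, para to a large group, gives a 1.1-fold lower number from compound 2 to compound 4 (0.03 log units; within the scatter), so at this position a single fluorine makes no readable difference. Substitution on this aromatic ring therefore does not move the number in every case: among the steps shown, only a 4.7-fold lower number from compound 2 to compound 3 (0.67 log units; beyond the scatter) lies beyond the scatter, and that step brings in trifluoromethyl at a different place on the ring. Nothing available here accounts for the contrast between the two steps.

The compounds shown leave open whether the contrast follows the group or its place, since trifluoromethyl and fluoro are not seen at the same place on the ring. They also leave open how a methoxy group or an amine would read at the position fluoro occupies in compound 4.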